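Swapping isopropyl for 2-cyanoethyl on the side chain

The source may hold more compounds than are shown below. What is called first, only, known or untested is meant among the compounds shown, and "the series" means these compounds.

- compound 1 `O=C1CS(=O)(=O)c2ccccc2N1Cc1nc2ccccc2n1CCCCF` gives 211000 nM as its value
- compound 2 `CC(C)CCn1c(CN2C(=O)CS(=O)(=O)c3ccccc32)nc2ccccc21` gives 63000 nM as its value

In an ADME assay on HEp-2 cells (Homo sapiens) for cytotoxicity (on this read-out lower numbers stand for higher toxicity in this test and higher numbers for lower toxicity in this test), compound 2 gives 63000 nM as the lower of the two numbers. Compound 3 `N#CCCCCn1c(CN2C(=O)CS(=O)(=O)c3ccccc32)nc2ccccc21` differs from it by 2-cyanoethyl in place of isopropyl on a saturated chain carbon, two bonds along the chain from an aromatic nitrogen with 2-cyanoethyl in place of isopropyl on a saturated chain carbon, two bonds along the chain from an aromatic nitrogen. For the measured compounds named here, the one measured step bearing on this is a 3.3-fold lower number from compound 1 to compound 2 (0.52 log units; beyond the scatter) with isopropyl entering at the same place. Here isopropyl leaves, so a modest step towards a higher number is expected in this assay on the strength of that single pair. The expected step is a 2.1-fold higher number from compound 2 to compound 3 (0.31 log units; beyond the scatter) and rests on no other data. For compound 3 the estimated value is 130000 nM with an expected range from 50000 nM to 300000 nM around it.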

Compound 3, half-maximal cytotoxic concentration: > 270000 nM
Compound 3 gave a limit, no number (the forecaster's own chance of this, stated with the estimate: 10%); at least 2.0-fold (0.31 log units) between middle value and limit.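

In this assay, compound 3 reaches a limit of the assay, not a number: the limit of > 270000 nM in this assay, at which 1 of the 3 values shown sits.

At this place on the side chain, 2-cyanoethyl in place of isopropyl gives an at least 4.2-fold higher number from compound 2 to compound 3 (0.63 log units; beyond the scatter), so the direction of this change is established. Cyano in place of fluoro gives an at least 1.2-fold higher number from compound 1 to compound 3 (0.10 log units; that floor lies within the scatter), which leaves no order between those two compounds.

On these data alone, how far compound 3 lies past its limit remains open, and with it the full size of both steps. Also open, as far as these compounds go, is whether an amine, a carboxylic acid or a longer chain at this place would give a similarly high number.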